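Swapping sulfo for hydroxysulfinyl at the assay limit

The compounds below may be only part of what the source reports. "The series", "measured", "known", "first", "only" and "open" are said of these compounds alone.

In a physicochemical assay for solubility, read by LC-MS, in phosphate buffer, measured as kinetic solubility, with a stated time of 24 h, at pH 7.4, tested at 200 uM (a lower number here means a less soluble compound, a higher number a more soluble compound), compound 1 `O=c1c(O)c(Cc2ccccc2)c1=O` gives 166000 nM as a measured number. Compound 2 `O=S(=O)(O)CCc1ccccc1` gives >= 200000 nM as a limit of the assay and not a number. Compound 3 `O=S(O)CCc1ccccc1` differs from compound 2 by hydroxysulfinyl in place of sulfo on a saturated chain carbon, two bonds along the chain from an aromatic carbon with hydroxysulfinyl in place of sulfo on a saturated chain carbon, two bonds along the chain from an aromatic carbon. For the measured compounds named here, no measured step covers this change. In this assay a downward step no larger than the scatter is expected, and an at least 1.1-fold lower number from compound 2 to compound 3 (0.04 log units; that floor lies within the scatter) is the estimated size. For compound 3 the expected value is 180000 nM in an estimated range from 110000 nM to 200000 nM at this stage.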

Compound 3, solubility: >= 200000 nM
Compound 3: a limit, no number; the forecaster's own chance of this, stated with the estimate: 55%; middle value at least 1.1-fold (0.04 log units) away from the limit.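

No step from compound 2 to compound 3 can be read, because both stand as limits and not as numbers: the limit of >= 200000 nM in this assay, at which 2 of the 3 values shown sit.

The compounds shown leave open what hydroxysulfinyl in place of sulfo does to the read-out in this assay.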